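From 3,5-dimethoxybenzyl to allyl on a shared core

This account rests on a few compounds, and the source may have more. Where it says the series, first, only, none or still open, it means among the compounds named here.

Of the compounds shown here, two have been measured in a functional assay on A549 cells (Homo sapiens) for inhibition, read by sulforhodamine B assay, with a stated time of 48 h; a higher number here means a weaker inhibitor, a lower number a stronger inhibitor. Compound 1 (`COc1ccc(C(c2ccc(O)cc2)c2cccc3ccccc23)c(OC)c1OC`) gives 16400 nM, and compound 2 (`COc1cc(COC(c2ccc(OC)c(OC)c2OC)c2cccc3ccccc23)cc(OC)c1`) gives 17500 nM. These two values lie within the scatter of each other, so compound 2 stands level with compound 1, and neither can be ranked above the other.

Compound 3 (`C=CCOC(c1ccc(OC)c(OC)c1OC)c1cccc2ccccc12`) has not yet been measured in this assay. It differs from compound 2 by having vinyl in place of 3,5-dimethoxyphenyl on a saturated chain carbon bound to an oxygen on a saturated carbon. The same difference, cut one bond further out, reads 3,5-dimethoxybenzyl to allyl.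

Within the data shown here, no step between measured compounds is available to guide the expectation, and the only anchor is the pair of values themselves. Compound 1 at 16400 nM and compound 2 at 17500 nM carry different groups and still sit close together, so no clear direction is expected. The estimated change, a 1.2-fold lower number from compound 2 to compound 3 (0.07 log units; within the scatter), is expected to stay within the scatter. For compound 3 the expected value is 15000 nM, with an estimated range from 6000 nM to 40000 nM.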

Compound 3, half-maximal inhibitory concentration: 9710 nM
Compound 3: middle estimate off by 1.5-fold (0.19 log units), on the high side, within the range that was stated.
By their numbers in this assay, from the lowest: compounds 3, 1 and 2 (each within the scatter of the next).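

In this assay, the step at this position removes a whole 3,5-dimethoxyphenyl, with its six-membered aromatic ring and two hydrogen-bond acceptors, and puts a vinyl in its place on a saturated chain carbon bound to an oxygen on a saturated carbon, giving a 1.8-fold lower number from compound 2 to compound 3 (0.26 log units; within the scatter). This shows that, among these compounds, a far smaller group without a ring at this place leaves the number within the scatter, something compounds 1 and 2 alone could not show. The second step, allyloxy in place of 4-hydroxyphenyl on a saturated chain carbon bound to two aromatic carbons, gives a 1.7-fold lower number from compound 1 to compound 3 (0.23 log units; within the scatter), so this change also does not separate the compounds, and no independent measurement is available here to bear on the result.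

The three compounds therefore show no change at these places that lies beyond the scatter, and they give no direction for further changes. On these data alone, it stays open whether a longer chain such as n-butyl, an amine or a carboxylic acid in place of the allyl would move the number beyond the scatter in this assay, or leave it level.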